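Swapping an aromatic ring for a saturated one on the core

A few compounds are considered here, and "the series" means these few. Any claim that something is new, unique, unknown or untested is made for them only; others in the source may bear on it.

Compound 1 `Fc1cccc(F)c1Cn1c(-c2c(F)cccc2F)nc2cnccc21`: in an ADME assay on MDBK cells (Bos taurus) for cytotoxicity (a lower number here means that less compound is tolerated, a higher number that more compound is tolerated), compound 1 gives > 100000 nM, which is a limit of the assay and not a number.
Compound 2 `Fc1cccc(F)c1Cn1cccc2nc(-c3c(F)cccc3F)nc1-2`: in this assay compound 2 gives > 100000 nM, again a limit.
Compound 3 `COc1cccc(Cn2ccc3nc(-c4ccccc4)nc-3c2)c1`: in this assay compound 3 gives > 100000 nM, also a limit.

Compound 3 therefore stands where every measured compound stands: at the limit of > 100000 nM in this assay, at which 3 of the 3 values shown sit. Among the measured compounds shown here, no true number separates the three, so no order among them can be read, and no step between measured compounds is available to calibrate a change.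

Compound 4 `c1ccc(-c2nc3ccn(CC4CCCCC4)cc-3n2)cc1` has not yet been measured in this assay. It differs from compound 3 in one place: cyclohexyl in place of 3-methoxyphenyl on a saturated chain carbon bound to an aromatic nitrogen. The shared core is untouched.

With all three neighbours sitting at the same limit, the expectation for compound 4 is that it too is tolerated up to the limit, so the step that the limit leaves unreadable from compound 3 to compound 4 is expected to be none beyond the scatter. Compound 4 is estimated at 120000 nM, with a likely range from 50000 nM to 300000 nM.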

Compound 4, half-maximal cytotoxic concentration: > 100000 nM
Compound 4 gave a limit, no number; the forecaster's own chance of this, stated with the estimate: 85%; the middle value is on the limit's open side.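

Compound 3 and compound 4 both give a limit rather than a true number, so no step can be read between them: the limit of > 100000 nM in this assay, at which 4 of the 4 values shown sit.

In this assay the compounds shown leave open whether 3-methoxyphenyl and cyclohexyl differ at all, and at what concentration any of these compounds stops being tolerated.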